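Substituent on the shared core: from compound 3 to compound 4

A few compounds are considered here, and "the series" means these few. Any claim that something is new, unique, unknown or untested is made for them only; others in the source may bear on it.

Measured so far in a functional assay on HEK293 cells for antagonist activity at transient receptor potential cation channel subfamily V member 1 (Rattus norvegicus); a lower number here means a stronger inhibitor, a higher number a weaker inhibitor:
compound 1 `CC(C)c1ccc(NC(=O)N2CCN(c3ncccc3[N+](=O)[O-])CC2)cc1` gives 245 nM
compound 2 `CC(C)c1ccc(NC(=O)N2CCN(c3ncccc3Br)CC2)cc1` gives 27.1 nM
compound 3 `Cc1cccnc1N1CCN(C(=O)Nc2ccc(C(C)C)cc2)CC1` gives 173 nM

Compound 3 sits second highest of the three numbers: compound 1 lies nearest, with a difference within the scatter (a 1.4-fold lower number from compound 1 to compound 3 (0.15 log units; within the scatter)), while compound 2 lies furthest, beyond the scatter (a 6.4-fold higher number from compound 2 to compound 3 (0.81 log units; beyond the scatter)).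

Compound 4 `CC(C)c1ccc(NC(=O)N2CCN(c3ncccc3C=O)CC2)cc1` is the next step. The change is formyl in place of methyl on an aromatic carbon. Going by the values given here, no measured step involves a formyl group, so the two steps that bear on it are only those exchanging the same ring position: nitro to methyl, within the scatter (a 1.4-fold lower number from compound 1 to compound 3 (0.15 log units; within the scatter)), and bromo to methyl, beyond the scatter (a 6.4-fold higher number from compound 2 to compound 3 (0.81 log units; beyond the scatter)). Of the three groups tried, only bromo moved the number clearly; nitro and methyl read alike. Among the compounds with values here, with no direct precedent, the step from compound 3 to compound 4 is expected to be about a 1.2-fold higher number from compound 3 to compound 4 (0.06 log units; within the scatter), that is, no change beyond the scatter in this assay. Compound 4 is therefore estimated at 200 nM, with a range from 60 nM to 700 nM.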

Compound 4, half-maximal inhibitory concentration: 1400 nM
The estimate for compound 4 lay 7.0-fold (0.85 log units) below the measured number; measured number outside the range, above it.
By their numbers in this assay, from the lowest: compound 2; then compounds 3 and 1 (each within the scatter of the next); then compound 4.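

In this assay, going by these compounds alone, formyl is the first group at this ring carbon to separate clearly from both methyl (an 8.1-fold higher number from compound 3 to compound 4 (0.91 log units; beyond the scatter)) and nitro (a 5.7-fold higher number from compound 1 to compound 4 (0.76 log units; beyond the scatter)), so the earlier agreement between nitro and methyl does not extend to every group placed here. The position now carries a much wider spread than bromo, nitro and methyl alone showed (a 52-fold higher number from compound 2 to compound 4 (1.71 log units; beyond the scatter)), and compound 4 is the weakest inhibitor of the four. No measurement available here explains why formyl reads apart from the other three groups.

Open, going by these compounds, is where an amine, a hydroxymethyl group or a carboxylic acid at this ring carbon would fall relative to bromo and formyl. Also open, on these data alone, is whether a chloro or an ethyl group would stay close to bromo or to methyl.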